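Compound 3 and the step to an anilino group

This account rests on a few compounds, and the source may have more. Where it says the series, first, only, none or still open, it means among the compounds named here.

In a functional assay on the whole organism with Mus musculus as the target (on this read-out lower numbers stand for an effect already at smaller amounts and higher numbers for an effect only at larger amounts of compound), compound 1 (`CNC(=O)[C@@H](C)NCc1ccc(OCc2ccccc2)cc1`) gives 40.5 mg/kg, compound 2 (`C[C@@H](NCc1ccc(Cc2ccccc2)cc1)C(N)=O`) gives 15.7 mg/kg and compound 3 (`C[C@@H](NCc1ccc(CCc2ccccc2)cc1)C(N)=O`) gives 40.3 mg/kg. Compound 3 thus lies within the scatter of compound 1, and its number is beyond the scatter of the lower one for compound 2. Going by the values given here, the only measured step at this place is modest: a 2.6-fold higher number from compound 2 to compound 3 (0.41 log units; beyond the scatter), with benzyl in place of phenyl. Compound 4 (`C[C@@H](NCc1ccc(CNc2ccccc2)cc1)C(N)=O`) differs from compound 3 by anilino in place of benzyl on a saturated chain carbon bound to an aromatic carbon. Among the compounds with values here, no measured step tests this exchange, so no change beyond the scatter is expected in this assay. The expected step is a 1.3-fold lower number from compound 3 to compound 4 (0.10 log units; within the scatter). The estimate for compound 4 is 32 mg/kg, within a range of 14 mg/kg to 75 mg/kg.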

Compound 4, dose for half-maximal effect: 119 mg/kg
Beside the measured number, compound 4's estimate is 3.7-fold (0.57 log units) below it, outside the stated range (above it).
By their numbers in this assay, from the lowest: compound 2; then compounds 3 and 1 (each within the scatter of the next); then compound 4.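

The exchange of benzyl for anilino keeps the heavy-atom count and the aromatic ring and swaps one carbon for one nitrogen, yet this assay shows a 3.0-fold higher number from compound 3 to compound 4 (0.47 log units; beyond the scatter). Measured against the phenyl of compound 2, anilino gives a 7.6-fold higher number from compound 2 to compound 4 (0.88 log units; beyond the scatter), so this place responds to a change of one atom within the chain as well as to the change from phenyl to benzyl. Nothing available here explains the rise.

Open remains whether the amine hydrogen of anilino matters, and what an N-methylanilino or phenoxy group would give at this place.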